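The source may hold more compounds than are shown below. What is called first, only, known or untested is meant among the compounds shown, and "the series" means these compounds.

- Compound 1 `Cn1c(=O)c(=O)n(C2CCCC2)c2nc(N/N=C/c3ccc(C(F)(F)F)cc3)ncc21`: 40600 nM
- Compound 2 `Cn1c(=O)c(=O)n(C2CCCC2)c2nc(N/N=C/c3ccco3)ncc21`: > 100000 nM

In a functional assay on A549 cells (Homo sapiens) for antiproliferative activity, read by MTT assay (on this read-out higher numbers stand for weaker inhibition and lower numbers for stronger inhibition), compound 2 gives > 100000 nM, which is a limit of the assay and not a number. Compound 3 `Cn1c(=O)c(=O)n(C2CCCC2)c2nc(N/N=C/c3ccc(F)cc3Cl)ncc21` carries 2-chloro-4-fluorophenyl in place of furan-2-yl on a carbon with a double bond to nitrogen. Going by the values given here, only one measured step bears on this change: an at least 2.4-fold higher number from compound 1 to compound 2 (0.39 log units; beyond the scatter). Its exchange runs the other way, so a step of at least similar size toward a lower number is expected here. The expected change is an at least 2.5-fold lower number from compound 2 to compound 3 (0.39 log units; beyond the scatter). For compound 3 the estimate is 40000 nM, with an expected range of 15000 nM to 100000 nM.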

Compound 3, half-maximal inhibitory concentration: 11000 nM
Compound 3: middle estimate off by 3.6-fold (0.56 log units), on the high side; measured number below the stated range.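

In this assay, 2-chloro-4-fluorophenyl on the carbon with a double bond to nitrogen gives an at least 9.0-fold lower number from compound 2 to compound 3 (0.95 log units; beyond the scatter). It also gives a 3.7-fold lower number from compound 1 to compound 3 (0.57 log units; beyond the scatter), so the read-out at this position differs between two substituted phenyl groups, not only between furan-2-yl and a phenyl group. The first step is only a bound, as compound 2 stands at a limit of the assay: the limit of > 100000 nM in this assay, at which 1 of the 3 values shown sits.

The compounds shown cannot separate the contribution of the chlorine from that of the fluorine. From the compounds shown here alone, how an unsubstituted phenyl, a saturated cyclohexyl or a phenyl carrying an amine would fare at this position remains open.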